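The compounds below may be only part of what the source reports. "The series", "measured", "known", "first", "only" and "open" are said of these compounds alone.

In a physicochemical assay for lipophilicity, at pH 7.4 (a lower number here means a more polar compound, a higher number a more lipophilic compound), compound 2 `CC(C)Oc1ccc(-c2nnc(-c3cnn(CC(=O)O)c3)s2)cc1Cl` gives 2.82, the lowest of the three measured numbers. Compound 3 `CC(C)Oc1ccc(-c2nnc(-n3cc4c(n3)CCN(CCCC(=O)O)C4)s2)cc1Cl` gives 3.56 and compound 1 `Cc1[nH]ncc1-c1nnc(-c2ccc(OC(C)C)c(Cl)c2)s1` gives 5.45, both beyond the scatter above compound 2. Compound 4 `CC(C)Oc1ccc(-c2nnc(-c3cn[nH]c3)s2)cc1Cl` has hydrogen in place of carboxymethyl on an aromatic nitrogen. Going by the values given here, no measured pair shows this change alone, so its size in this assay must be inferred. The closest measured structure to compound 4 appears to be compound 1 at 5.45, so a large upward step, well beyond the scatter, is expected. The expected change is estimated as a number 2.08 log units higher from compound 2 to compound 4 (beyond the scatter). For compound 4 the estimated value is 4.9, with an expected range from 4.4 to 5.4.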

Compound 4, distribution coefficient: 5
Compound 4: the middle estimate sits 0.10 log units below what was measured, within the range that was stated.
By their numbers in this assay, from the lowest: compound 2; then compound 3; then compound 4; then compound 1.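

In this assay, the swap of carboxymethyl for hydrogen on the aromatic nitrogen now stands alone as a single change, and it gives a number 2.18 log units higher from compound 2 to compound 4 (beyond the scatter) on the shared core. The aromatic carbon of the same ring also registers a single change, hydrogen in place of methyl, with a number 0.45 log units lower from compound 1 to compound 4 (beyond the scatter) as a smaller step than the one on the nitrogen. No measurement shown gives a reason for either step. Open, on these data alone, is where an acetamide or a hydroxyethyl chain on that aromatic nitrogen would fall in this assay relative to hydrogen and carboxymethyl.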